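Replacing bromine with methyl on a shared core

The source may report more compounds than this note shows. Statements on the series, on what has been measured and on what is new or still open speak of the compounds shown alone.

Of the compounds shown here, three have been measured in a functional assay on the whole organism for inhibition, with Mus musculus as the target, with a stated time of 4 h, at a dose of 50 mg/kg by the oral route; a lower number here means less inhibition, a higher number more inhibition at the dose given (going by the name of the read-out). Compound 2 `Cc1cc2ncc(S(=O)(=O)c3ccccc3)c(-c3ccc(Br)cc3)n2n1` gives 0%. Compound 1 `Cc1ccc(-c2c(S(=O)(=O)c3ccccc3)cnc3cc(C)nn23)cc1` gives 14% in this assay. Between these two the change is methyl in place of bromo on an aromatic carbon. The step that goes with it, a number 14 percentage points higher from compound 2 to compound 1 (beyond the scatter), is modest. Compound 3 `Cc1ccc(-c2c(S(=O)(=O)c3ccccc3)cnc3cc(-c4ccc(Br)cc4)nn23)cc1` gives 26.6% in this assay, the highest of the three. It differs from compound 1 by 4-bromophenyl in place of methyl on an aromatic carbon, and the step is a number 12.6 percentage points higher from compound 1 to compound 3 (beyond the scatter). The difference between the cores of compound 3 and compound 2 is not broken down here. Compound 4 `Cc1ccc(-c2cc3ncc(S(=O)(=O)c4ccccc4)c(-c4ccc(C)cc4)n3n2)cc1` has not yet been measured. It differs from compound 3 by methyl in place of bromo on an aromatic carbon. This is the same change already seen from compound 2 to compound 1, made at the same kind of place. Because that earlier step was a number 14 percentage points higher from compound 2 to compound 1 (beyond the scatter), a rise of a broadly similar size is expected here. The step to compound 4 is therefore estimated as a number 11.4 percentage points higher from compound 3 to compound 4 (beyond the scatter). On that basis compound 4 is expected to give 38% in this assay, likely between 20% and 55%.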

Compound 4, a percentage reported as inhibition, in the whole organism at one dose (the size of the read-out at that dose, not a potency): 20%
Estimate against measurement, compound 4: 18 percentage points above, and the stated range covers the measured number.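

In this assay, methyl in place of bromo did not carry over from one core to the other as a fixed step: the same change on two cores in this assay, a number 14 percentage points higher (beyond the scatter) from compound 2 to compound 1 and a number 6.6 percentage points lower (within the scatter) from compound 3 to compound 4, 20.6 percentage points apart, beyond the scatter of two such steps. On the core of compound 3 the same change gives a number 6.6 percentage points lower from compound 3 to compound 4 (within the scatter), and 4-methylphenyl in place of methyl gives a number 6 percentage points higher from compound 1 to compound 4 (within the scatter), so neither step shows a clear effect of the group that was changed. Among the compounds shown here, with only two pairs, each read at one dose in one assay, the data show that the step from one core cannot be assumed for the other, but they do not show why the cores differ or what a further core would do.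

The groups that vary here are only bromo, methyl and the phenyl rings carrying them. As far as these compounds go, whether an amine, a carboxylic acid or a longer chain at the same place on the six-membered aromatic ring of carbon only would give a step beyond the scatter on either core remains open.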